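Long chain on a nitrogen, with no baseline number

The source may hold more compounds than are shown below. What is called first, only, known or untested is meant among the compounds shown, and "the series" means these compounds.

Measured in a functional assay on HCT-116 cells (Homo sapiens) for cytotoxicity, read by MTT assay, with a stated time of 72 h; a higher number here means a weaker inhibitor, a lower number a stronger inhibitor:
compound 1 `Nc1cccc(Nc2c(C(=O)NCc3ccc(F)cc3)nc(Br)c3cccnc23)c1`: > 10000 nM (a limit)
compound 2 `CNc1c(C(=O)NCc2ccc(F)cc2)nc(Br)c2cccnc12`: > 20000 nM (a limit)
compound 3 `C[C@@H](CO)Nc1nc(C(=O)NCc2ccc(F)cc2)c(O)c2ncccc12`: "not determined" (no result reported)

Compound 3 offers no number to start from, as its entry reads "not determined" (no result reported). Compound 1 gives > 10000 nM, which is a limit and not a number. Compound 2 gives > 20000 nM, which is also a limit.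

Compound 4 `O=CNCCCCCCNc1nc(C(=O)NCc2ccc(F)cc2)c(O)c2ncccc12` keeps the core of compound 3 and changes one group: 6-(formylamino)hexyl in place of 1-(hydroxymethyl)ethyl on a nitrogen on an aromatic ring. A 6-(formylamino)hexyl group takes the place of 1-(hydroxymethyl)ethyl on a nitrogen on an aromatic ring, and the defined stereocentre leaves with it.

For the measured compounds named here, the one measured step, a step that the two limits leave unreadable from compound 1 to compound 2, is also a swap of the group on such a nitrogen, but its size cannot be read. The core of compound 1 also differs from that of compound 3. Going by the values given here, no step of any size or direction can therefore be expected for this change, and only a level can be estimated. The limit of compound 2 at > 20000 nM leans that level toward weak inhibition, though loosely given the different core. For compound 4 the expected value in this assay is estimated at 4000 nM, within a range of 600 nM to 20000 nM.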

Compound 4, half-maximal inhibitory concentration: 6000 nM
For compound 4 the middle estimate is 1.5-fold (0.18 log units) below the measured one; the measured number falls inside the stated range.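

No step can be read from compound 3 to compound 4: in this assay compound 4 gives 6000 nM, while compound 3 has no reported result. On these data alone, whether 6-(formylamino)hexyl in place of 1-(hydroxymethyl)ethyl strengthens or weakens inhibition in this assay therefore stays open, and nothing measured here bears on compound 4's value.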